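Swapping the benzyl of compound 1 for a thiourea-type substituent

The source may report more compounds than this note shows. Statements on the series, on what has been measured and on what is new or still open speak of the compounds shown alone.

Working notes on a small set of fused bicyclic amides. The read-out throughout is a functional assay on MKN-74 cells (Homo sapiens) for antiproliferative activity, with a stated time of 24 h; a higher number here means a weaker inhibitor, a lower number a stronger inhibitor. Compound 1, `NC(=O)c1c(NC(=O)c2ccccc2Cl)sc2c1CCN(Cc1ccccc1)C2`, gives 14500 nM. Compound 2, `Cc1ccc(C(=O)Nc2sc3c(c2C(N)=O)CCN(Cc2ccc(Cl)cc2Cl)C3)cc1`, gives 25500 nM. Compound 3, `NC(=O)c1c(NC(=O)c2ccccc2F)sc2c1CCN(Cc1cccc(Cl)c1)C2`, gives 23300 nM. Compound 1 carries the lowest number of the three, but its gaps to compound 3 and to compound 2 both fall within the scatter of repeated measurements, so the three values cannot be ordered; all three sit at weak potency.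

The next compound, compound 4, is `NC(=O)c1c(NC(=O)c2ccccc2Cl)sc2c1CCN(C(=S)Nc1ccccc1)C2`. It differs from compound 1 in one place: a group of 9 heavy atoms (7 carbon, 1 nitrogen, 1 sulfur; one six-membered aromatic ring of carbon only) in place of a group of 7 heavy atoms (7 carbon; one six-membered aromatic ring of carbon only), on an amine nitrogen in a ring. Among the compounds with values here, no pair of measured compounds shows this kind of change, so there is no measured step to lean on; the only anchor is that compound 1 gives 14500 nM and its two neighbours do not move beyond the scatter with changes at that same ring nitrogen.

Within the data shown here, with no relevant step in hand, the expectation is that the value for compound 4 stays close to that of compound 1, with any movement expected to remain within the scatter, as expressed by a 1.2-fold higher number from compound 1 to compound 4 (0.09 log units; within the scatter). The estimate for compound 4 in this assay is 18000 nM, with a range from 6000 nM to 55000 nM.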

Compound 4, half-maximal inhibitory concentration: 15600 nM
Compound 4: middle estimate off by 1.2-fold (0.06 log units), on the high side; measured number inside the range.
By their numbers in this assay, from the lowest: compounds 1, 4, 3 and 2 (each within the scatter of the next).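

In this assay, within the data shown here, the change from benzyl to the thiourea-type group on the amine nitrogen in a ring gives the first one-place step, a 1.1-fold higher number from compound 1 to compound 4 (0.03 log units; within the scatter). This shows that, with the rest of the core of compound 1 held fixed, this position takes a group with a double bond outside aromatic rings, a hydrogen-bond donor and a hydrogen-bond acceptor in place of benzyl, with no change in the number beyond the scatter; both groups keep a six-membered aromatic ring of carbon only, so this single step says nothing about losing that ring. No supporting measurement bears on why the step is this small.

The compounds shown leave open whether the sulfur of the new group matters, a question that the urea with oxygen in its place would address, and whether the aromatic ring matters, which a methyl group or the free ring amine at the same nitrogen would test. As far as these compounds go, it also remains open whether any group at this nitrogen can move the series away from its present weak potency, as a basic aminoethyl chain or a carboxylic acid on the chain might show.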